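A few compounds are considered here, and "the series" means these few. Any claim that something is new, unique, unknown or untested is made for them only; others in the source may bear on it.

Of the compounds shown here, two have so far been measured in an ADME assay on microsomes from liver (Mus musculus) for metabolic stability, read by LC-MS, using NADPH, tested at 1 uM; on this read-out higher numbers stand for a longer-lived compound and lower numbers for a shorter-lived compound. Compound 1 `CCCC(=O)NC/C=C\CN(C)C[C@H]1O[C@@H](n2cnc3c(N)ncnc32)[C@H](OC(C)=O)[C@@H]1OC(C)=O` gives 0.05 h, a short half-life on this read-out. Compound 2 `CNc1ncnc2c1ncn2[C@@H]1O[C@H](CN(C)C/C=C\CN)[C@H]2OC(C)(C)O[C@H]21` gives > 1.5 h, which is a limit of the assay and not a number. From the compounds shown here alone, that places compound 2 at the limit of > 1.5 h in this assay, at which 1 of the 2 values shown sits, so its true half-life remains unknown.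

The next compound to be tested is compound 3 `CCCCCCCCC(=O)Nc1ncnc2c1ncn2[C@@H]1O[C@H](CN(C)C/C=C\CN)[C@H]2OC(C)(C)O[C@H]21`. It differs from compound 2 in one place, with octylcarbonyl in place of methyl on a nitrogen on an aromatic ring. For the measured compounds named here, no measured pair of compounds shows what a change of this kind does, so any forecast here is rough. A fall in half-life beyond the usual scatter is expected, though a result at the limit of this assay remains possible. This expectation leans on compound 1, whose 0.05 h shows how short-lived a compound in this small set can be. The estimated change is an at least 5.0-fold lower number from compound 2 to compound 3 (0.69 log units; beyond the scatter). For compound 3 the expected half-life is 0.3 h, with an estimated range of 0.07 h to 1.3 h.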

Compound 3, half-life: 0.1 h
Beside the measured number, compound 3's estimate is 3.0-fold (0.48 log units) above it; the measured number falls inside the stated range.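

In this assay, for the compounds shown here, putting octylcarbonyl in place of methyl on a nitrogen on an aromatic ring gives an at least 15-fold lower number from compound 2 to compound 3 (1.17 log units; beyond the scatter), the first measured step in this set and the first sign that the group on this nitrogen can strongly alter half-life. The true size of this step is not known and could be larger, because the value of compound 2 is a limit of the assay and not a number: the limit of > 1.5 h in this assay, at which 1 of the 3 values shown sits. Read one bond further out, the change is methylamino to (octylcarbonyl)amino, which means that a single swap brings in both a carbonyl and a long carbon chain.

This one step cannot show whether the carbonyl, the chain or both go with the shorter half-life, and an acetyl group or a plain octyl chain on the same nitrogen would be needed to separate the two. Compound 1 differs from compound 2 and compound 3 in more than one place, which leaves open whether the same change would have a similar effect on its core.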